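Fluoro for methoxy: compound 1 to compound 4

This account rests on a few compounds, and the source may have more. Where it says the series, first, only, none or still open, it means among the compounds named here.

Measured in an ADME assay on HepG2 cells (Homo sapiens) for cytotoxicity, with a stated time of 72 h (a higher number here means that more compound is needed for the effect, a lower number that less compound is needed), as half-maximal effective concentration:
- compound 1 `COc1ccc(-c2nc3ccccc3o2)cc1NC(=O)c1cc([N+](=O)[O-])ccc1Cl` gives > 25000 nM as a limit
- compound 2 `COc1ccc(-c2nc3ccccc3s2)cc1NC(=O)c1cc([N+](=O)[O-])ccc1Cl` gives > 25000 nM as a limit
- compound 3 `Cc1c(NC(=O)c2cc([N+](=O)[O-])ccc2Cl)cccc1-c1nc2ccccc2s1` gives > 25000 nM as a limit

Compound 1 has no numeric value, only the limit > 25000 nM in this assay as its reading. It shares this position with the other two compounds, as shown by the limit of > 25000 nM in this assay, at which 3 of the 3 values shown sit, in this small set.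

Compound 4 `O=C(Nc1cc(-c2nc3ccccc3o2)ccc1F)c1cc([N+](=O)[O-])ccc1Cl` differs from compound 1 by fluoro in place of methoxy on an aromatic carbon with fluoro in place of methoxy on an aromatic carbon, ortho to a large group and para to a 1,3-benzoxazol-2-yl group.

Going by the values given here, the only measured step is a step that the two limits leave unreadable from compound 1 to compound 2 with 1,3-benzothiazol-2-yl in place of 1,3-benzoxazol-2-yl on an aromatic carbon. That step has no readable size and involves a different place on the structure, so it gives no size or direction to carry over. Among the compounds with values here, no measured step covers the exchange of methoxy for fluoro.

Given the limit of > 25000 nM in this assay, at which 3 of the 3 values shown sit, as the only guide, compound 4 is expected to show no step beyond the scatter, and another limit is the likeliest reading. The expected step is a number no higher from compound 1 to compound 4 (the limit leaves the size open) in this assay on this reasoning. The estimated value for compound 4 is 25000 nM with an expected range of 12000 nM to 50000 nM if a number is reported.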

Compound 4, half-maximal effective concentration: > 25000 nM
Compound 4: a limit, no number; the forecaster's own chance of this, stated with the estimate: 75%; the middle value sits exactly at the limit.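

In this assay, going by these compounds alone, compound 1 and compound 4 are both recorded only as limits, so no step between them can be read. The compounds shown leave open what number any of them would give, and therefore what fluoro in place of methoxy does to the read-out, with all of them at one reading: the limit of > 25000 nM in this assay, at which 4 of the 4 values shown sit.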